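A few compounds are considered here, and "the series" means these few. Any claim that something is new, unique, unknown or untested is made for them only; others in the source may bear on it.

Three compounds share one core, differing only in the groups attached to it. Compound 1 `NS(=O)(=O)c1ccc(N2N=C(c3ccc(Oc4ccccc4)cc3)CC2c2ccccc2Cl)cc1` carries a chlorophenyl group on the saturated ring of that core; compound 2 `Cc1ccc(C2CC(c3ccc(OCc4ccccc4)cc3)=NN2c2ccc(S(N)(=O)=O)cc2)cc1` and compound 3 `Cc1cccc(C2CC(c3ccc(OCc4ccccc4)cc3)=NN2c2ccc(S(N)(=O)=O)cc2)c1` carry a methylphenyl group there instead, with the methyl at different positions. In an ADME assay on Vero 76 cells (Chlorocebus sabaeus) for cytotoxicity, read by MTT assay, with a stated time of 96 h (a lower number here means that less compound is tolerated, a higher number that more compound is tolerated), compound 1 gives 29000 nM, the lowest of the three numbers, so compound 1 is the least tolerated of the set. In this assay compound 2 gives 100000 nM and compound 3 gives 100000 nM. For the measured compounds named here, the one measured step, no change at the digits printed from compound 2 to compound 3 (within the scatter), moves the methyl between positions on the phenyl ring and leaves the number where it was.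

Compound 4 `Cc1ccccc1C1CC(c2ccc(Oc3ccccc3)cc2)=NN1c1ccc(S(N)(=O)=O)cc1` arises from compound 1 by methyl in place of chloro on an aromatic carbon. Going by the values given here, no measured step touches this exchange of chloro for methyl on an aromatic carbon; the only step concerns a different position and shows no change, so the expectation is a step in this assay that stays within the scatter. The estimated value for compound 4 is therefore 35000 nM, between 15000 nM and 100000 nM, which is expected to be a step of a 1.2-fold higher number from compound 1 to compound 4 (0.08 log units; within the scatter).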

Compound 4, half-maximal cytotoxic concentration: 90000 nM
Beside the measured number, compound 4's estimate is 2.6-fold (0.41 log units) below it, and the stated range covers the measured number.
By their numbers in this assay, from the lowest: compound 1; then compounds 4, 2 and 3 (each within the scatter of the next).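

Exchanging chloro for methyl on an aromatic carbon, ortho to a large group, gives a 3.1-fold higher number from compound 1 to compound 4 (0.49 log units; beyond the scatter). The earlier step, no change at the digits printed from compound 2 to compound 3 (within the scatter), moved a methyl around the ring without changing the number, whereas this one shows that the number in this assay can respond to a change of a single heavy atom, even though the counts of rings, hydrogen-bond donors, hydrogen-bond acceptors and net charge stay the same. Nothing available explains why this exchange raises the number.

The compounds shown do not tell how a methoxy group or an amine would read at this place, so it remains open whether the tolerated concentration follows any trend across groups. As far as these compounds go, it also remains open whether chloro and methyl would differ in the same way on a compound with the rest of its structure as in compound 2.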